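Vero cytotoxicity: from compound 1 to compound 4

The compounds below may be only part of what the source reports. "The series", "measured", "known", "first", "only" and "open" are said of these compounds alone.

The series shares one core, carried by compound 1 `CCN(CC)c1cc2[nH]c(C3CCCCC3)nc2cc1NC(=O)c1cnccn1`, compound 2 `CN(C)c1cc2[nH]c(C3CCCCC3)nc2cc1NC(=O)c1ccc(Br)cc1` and compound 3 `CCCc1ccc(C(=O)Nc2cc3nc(C4CCCCC4)[nH]c3cc2N(C)C)cc1`. In an ADME assay on Vero cells (Chlorocebus sabaeus) for cytotoxicity, read by resazurin assay, with a stated time of 3 days (on this read-out higher numbers stand for weaker inhibition and lower numbers for stronger inhibition), compound 1 gives > 100 ug/mL, which is a limit of the assay and not a number. Compound 2 likewise gives > 100 ug/mL, again a limit. Compound 3 gives > 100 ug/mL, also a limit. Compound 1 therefore stands where every value shown stands, at the limit of > 100 ug/mL in this assay, at which 3 of the 3 values shown sit, and nothing separates the three. Among the compounds with values here, the only step between measured compounds, a step that the two limits leave unreadable from compound 2 to compound 3, puts propyl in place of bromo on an aromatic carbon, with both ends at the limit.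

Compound 4 `CCOCCOC(=O)Nc1cc2nc(C3CCCCC3)[nH]c2cc1N(CC)CC` is not yet measured; it differs from compound 1 by 2-ethoxyethoxy in place of pyrazin-2-yl on a carbonyl carbon. Within the data shown here, no measured step touches the carbonyl side, so the only bearing evidence is the limit of > 100 ug/mL in this assay, at which 3 of the 3 values shown sit, which gives no direction. Because of the limit of > 100 ug/mL in this assay, at which 3 of the 3 values shown sit, no step beyond the scatter is expected for compound 4 in this assay, and the expected step of a number no higher from compound 1 to compound 4 (the limit leaves the size open) is flat. Compound 4 is estimated at 100 ug/mL, within 50 ug/mL to 200 ug/mL, with a limit again the most likely report.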

Compound 4, half-maximal inhibitory concentration: > 100 ug/mL
Compound 4: only a limit was reported (the forecaster's own chance of this, stated with the estimate: 85%); the middle value sits exactly at the limit.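

In this assay compound 4 gives > 100 ug/mL and this is a limit, not a number. Compound 1 and compound 4 both stand at a limit, and no new step can be read between them. The compounds shown leave open whether any change on the shared core gives a readable value.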